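The compounds below may be only part of what the source reports. "The series", "measured", "known", "first", "only" and "open" are said of these compounds alone.

Compound 1 `COc1cc2c(cc1OC)C(CC(=O)Nc1ccc(Cl)cc1)CC2`: 70%
Compound 2 `COc1cc2c(cc1OC)C(CC(=O)Nc1ccccc1C)CC2`: 23.3%

In a functional assay on the whole organism (strain Wistar) for inhibition, with Rattus norvegicus as the target, read by paw edema, with a stated time of 24 h, at a dose of 100 mg/kg (a higher number here means more inhibition at the dose given (going by the name of the read-out), a lower number less inhibition), compound 2 holds the lower of the two numbers, the gap being a number 46.7 percentage points lower from compound 1 to compound 2 (beyond the scatter). Compound 3 `COc1cc2c(cc1OC)C(CC(=O)Nc1ccc(C)cc1)CC2` differs from compound 2 by 4-methylphenyl in place of 2-methylphenyl on an amide-type nitrogen. Among the compounds with values here, the only measured step, a number 46.7 percentage points lower from compound 1 to compound 2 (beyond the scatter), swapped 4-chlorophenyl for 2-methylphenyl and does not isolate the moving of the methyl, though it shows that the pattern on this phenyl can shift this assay strongly. Compound 3 is therefore expected to rise by a number 21.7 percentage points higher from compound 2 to compound 3 (beyond the scatter), with wide uncertainty. The estimate for compound 3 is 45%, between 20% and 70%.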

Compound 3, a percentage reported as inhibition, in the whole organism at one dose (the size of the read-out at that dose, not a potency): 30%
For compound 3 the middle estimate is 15 percentage points above the measured one, within the range that was stated.
By their numbers in this assay, from the lowest: compounds 2 and 3 (each within the scatter of the next); then compound 1.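

With the step of a number 6.7 percentage points higher from compound 2 to compound 3 (within the scatter) in this assay, 2-methylphenyl and 4-methylphenyl on the amide-type nitrogen cannot be told apart. Methyl in place of chloro on an aromatic carbon, by contrast, gives a number 40 percentage points lower from compound 1 to compound 3 (beyond the scatter), so the earlier gap now appears with the methyl held at the same place as the chloro, and among these three compounds the higher number stands with compound 1 alone. Nothing available explains this difference.

On these data alone, whether a bromo, a methoxy or a carboxylic acid in place of the chloro would keep the inhibition of compound 1 remains open. So does the role of the two methoxy groups on the shared core, which are the same in all three compounds.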